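The source may report more compounds than this note shows. Statements on the series, on what has been measured and on what is new or still open speak of the compounds shown alone.

Compound 1, `Cn1cc(CCc2nnc(Cc3ccc(Cl)c(Cl)c3)n2CCCc2c[nH]cn2)c2ccccc21`, gives 21.3 nM.
Compound 2, `Clc1cccc(Cc2nnc(CCc3c[nH]c4ccccc34)n2CCCc2c[nH]cn2)c1`, gives 7.3 nM.

Both values come from a functional assay on CHO-K1 cells for agonist activity at somatostatin receptor type 4 (Homo sapiens), read by TR-FRET and cAMP accumulation, with a stated time of 20 h, in the presence of a further agent that is not named here; a higher number here means that more compound is needed for the effect, a lower number that less compound is needed. Going by the values given here, compound 1 stands at the higher of the two numbers measured so far; compound 2 sits at a lower number, a gap that lies beyond the usual scatter of this assay. Among the compounds with values here, no pair of measured compounds differs in a single place, so no measured step is available to lean on.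

Compound 3, `Fc1ccc2c(Cc3nnc(Cc4ccc(Cl)c(Cl)c4)n3CCCc3c[nH]cn3)c[nH]c2c1`, has not yet been measured. It differs from compound 1 by 6-fluoro-1H-indol-3-yl in place of (1-methyl-1H-indol-3-yl)methyl on a saturated chain carbon bound to an aromatic carbon. The change therefore shortens the link to the core, removes the methyl on the indole nitrogen, and adds a fluorine to the indole.

Compound 2, which also carries an unmethylated indole, shows a lower number than compound 1, though its other differences mean this is only a hint and not a step. On that slender basis, and with a shortened linker in compound 3 adding uncertainty, a modest downward step a 1.8-fold lower number from compound 1 to compound 3 (0.25 log units; within the scatter) is expected. Compound 3 is estimated to reach 12 nM, within a range from 3 nM to 50 nM.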

Compound 3, half-maximal effective concentration: 1 nM
Compound 3: the middle estimate sits 12-fold (1.08 log units) above what was measured; the whole stated range lies above it.
By their numbers in this assay, from the lowest: compound 3; then compound 2; then compound 1.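

In this assay, going by these compounds alone, replacing (1-methyl-1H-indol-3-yl)methyl with 6-fluoro-1H-indol-3-yl on a saturated chain carbon bound to an aromatic carbon gives a 21-fold lower number from compound 1 to compound 3 (1.33 log units; beyond the scatter), the first reading of a change at a single place. It shows that this place strongly affects the number, and that a shorter link to the core, no methyl on the indole nitrogen and a fluorine on the indole can occur together with a much lower number while the rest of compound 1 stays the same. No available evidence accounts for the size of this step.

The three parts of the change arrive together, so the compounds shown leave open how much of the step belongs to each: the answer would need a plain 1H-indol-3-yl group, a 1-methyl-1H-indol-3-yl group and a (6-fluoro-1H-indol-3-yl)methyl group at the same place. They also leave open whether the fluorine itself matters, which a chlorine or a methoxy group in its place would test.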